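Swapping cyclopentyl for benzyl on an inhibitor

The compounds below may be only part of what the source reports. "The series", "measured", "known", "first", "only" and "open" are said of these compounds alone.

Compound 1 `CC(/N=c1\c(O)c(O)\c1=N/c1ccc(C#N)cc1)C(C)(C)C`: 520 nM
Compound 2 `N#Cc1ccc(Nc2c(NC3CCCC3)c(=O)c2=O)cc1`: 11500 nM

In a functional assay for inhibition, with Rattus norvegicus as the target (on this read-out lower numbers stand for stronger inhibition and higher numbers for weaker inhibition), compound 2 gives the higher of the two numbers, 11500 nM, so it is the weaker inhibitor. Compound 1 gives 520 nM, a clearly lower number, and the gap lies beyond the usual scatter.

Compound 3 `N#Cc1ccc(Nc2c(NCc3ccccc3)c(=O)c2=O)cc1` has not yet been measured. It carries benzyl in place of cyclopentyl on a nitrogen on an aromatic ring. Among the compounds with values here, no measured pair of compounds differs in this one place alone, so the expectation rests on thin evidence. In this assay, a small move toward a lower number is expected, not clearly beyond the scatter. The expected change is a 1.9-fold lower number from compound 2 to compound 3 (0.28 log units; within the scatter). Compound 3 is estimated at 6000 nM, with an expected range of 1300 nM to 28000 nM.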

Compound 3, half-maximal inhibitory concentration: > 30000 nM
Compound 3 was reported as a limit; the forecaster's own chance of this, stated with the estimate: 10%; at least 5.0-fold (0.69 log units) between middle value and limit.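

In this assay compound 3 gives > 30000 nM, which is a limit of the assay and not a number. Benzyl in place of cyclopentyl on this nitrogen gives an at least 2.6-fold higher number from compound 2 to compound 3 (0.41 log units; beyond the scatter), so the first direct comparison at this position shows that the group placed here matters, and that this swap weakens inhibition rather than improving it. The step is only a minimum, because it rests on a limit, so how much weaker compound 3 really is stays unknown: the limit of > 30000 nM in this assay, at which 1 of the 3 values shown sits.

The compounds shown leave open how an open chain, such as butyl, or a chain ending in an amine or a carboxylic acid, would behave on this nitrogen. Cyclohexyl, a non-aromatic six-membered ring of carbon only, would help show whether the aromatic ring or the larger group size goes with the weaker inhibition.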